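The source may report more compounds than this note shows. Statements on the series, on what has been measured and on what is new or still open speak of the compounds shown alone.

Working notes on the series. Two compounds sharing one core have been run in a functional assay on HepG2 cells (Homo sapiens) for inhibition, read by sulforhodamine B assay, with a stated time of 72 h, tested at 10 uM (a lower number here means less inhibition, a higher number more inhibition at the concentration tested (going by the name of the read-out)), so far. Compound 1, `C[C@H](Nc1nc(N)nc2[nH]cnc12)c1nn(-c2cccnc2)c2cc(F)ccc12`, gives 11% in this assay. Compound 2, `C[C@H](Nc1ncnc2[nH]cnc12)c1nn(-c2ccc(C#N)cc2)c2cc(F)ccc12`, gives 57% in this assay, the higher of the two numbers; the gap to compound 1 lies beyond the usual scatter of repeated measurements. Among the measured compounds shown here, compound 1 and compound 2 differ in more than one place, so the two values show only that the pair sits far apart, not which change carries the gap.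

The next compound, compound 3, is `C[C@H](Nc1ncnc2[nH]cnc12)c1nn(-c2ccncc2)c2cc(F)ccc12`. Relative to compound 2 it carries pyridin-4-yl in place of 4-cyanophenyl on an aromatic nitrogen. The rest of the structure is kept.

For the measured compounds named here, with no single-change step between measured compounds, the direction of this change cannot be read off the data. The only other six-membered ring with one hetero atom on that aromatic nitrogen belongs to compound 1, whose low value 11% also reflects a second change on the core. The working expectation for compound 3 is therefore a loss relative to compound 2, a number 27 percentage points lower from compound 2 to compound 3 (beyond the scatter), of moderate size. Compound 3 is estimated at 30% in this assay, in the range 5% to 60%.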

Compound 3, a percentage reported as inhibition, at one concentration (the size of the read-out at that concentration, not a potency): 47%
Beside the measured number, compound 3's estimate is 17 percentage points below it; the range from low to high includes it.
By their numbers in this assay, from the lowest: compound 1; then compounds 3 and 2 (each within the scatter of the next).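

Among the compounds shown here, replacing 4-cyanophenyl with pyridin-4-yl on the aromatic nitrogen gives the first single-change step in this assay, a number 10 percentage points lower from compound 2 to compound 3 (within the scatter). At this position, then, the nitrile-bearing carbon ring and the ring with one hetero atom cannot be told apart by this read-out, so the loss of the nitrile and the entry of a ring nitrogen together leave no effect that stands clear of the scatter. No accompanying measurement bears on this step, and the notes can therefore record only its size.

Compound 1 differs from both compound 2 and compound 3 in more than one place, so its steps to them cannot be read, and the share of its low value owed to the core and the share owed to the ring on the aromatic nitrogen stay unresolved. Also open, going by these compounds, is how the position responds to groups of a different kind, such as a morpholine, a carboxylic acid or a short alkyl chain in place of the aromatic ring, since both rings compared here are six-membered and aromatic.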